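Swapping methyl for ethoxy on a weakly active compound

The source may hold more compounds than are shown below. What is called first, only, known or untested is meant among the compounds shown, and "the series" means these compounds.

In a functional assay on L1210 cells (Mus musculus) for antiproliferative activity, with a stated time of 48 h (on this read-out lower numbers stand for stronger inhibition and higher numbers for weaker inhibition), compound 3 (`Cc1ccc(C(=O)/C=C/c2ccc(N)cc2)cc1`) gives 49000 nM. That sits within the scatter of compound 2 (`Nc1ccc(/C=C/C(=O)c2ccccc2)cc1`), which gives 88000 nM. Compound 1 (`C=C(Br)C(=O)Nc1ccc(/C=C/C(=O)c2ccc(OCC)cc2)cc1`) gives a far lower number, 240 nM.

The compound to be measured next is compound 4 (`CCOc1ccc(C(=O)/C=C/c2ccc(N)cc2)cc1`). It keeps the core of compound 3 and changes one group: ethoxy in place of methyl on an aromatic carbon. In words, ethoxy takes the place of methyl on an aromatic carbon.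

Among the compounds with values here, the one measured step that bears directly on this change replaced hydrogen with methyl on the same aromatic carbon. That step is a 1.8-fold lower number from compound 2 to compound 3 (0.25 log units; within the scatter), so this carbon has not yet shown a response larger than the noise of the measurement. Compound 1 also carries ethoxy, but its nitrogen bears a further group as well, so the data hold no clean measure of ethoxy alone. That leaves no firm ground for predicting a large change in either direction.

Only a small shift, no larger than the scatter, is expected, and the estimated step is a 1.2-fold lower number from compound 3 to compound 4 (0.09 log units; within the scatter). The estimate for compound 4 is 40000 nM, with an expected range from 15000 nM to 100000 nM.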

Compound 4, half-maximal inhibitory concentration: 21000 nM
Compound 4: the middle estimate sits 1.9-fold (0.28 log units) above what was measured; low and high end bracket the measured number.
By their numbers in this assay, from the lowest: compound 1; then compound 4; then compounds 3 and 2 (each within the scatter of the next).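

In this assay, within the data shown here, this aromatic carbon now gives a step beyond the scatter for the first time: methyl had left the number within the scatter, at a 1.8-fold lower number from compound 2 to compound 3 (0.25 log units; within the scatter), whereas ethoxy in place of methyl gives a 2.3-fold lower number from compound 3 to compound 4 (0.37 log units; beyond the scatter), and ethoxy in place of hydrogen gives a 4.2-fold lower number from compound 2 to compound 4 (0.62 log units; beyond the scatter). Compound 4 also separates the two differences carried by compound 1, since only the group on the nitrogen changes in an 88-fold higher number from compound 1 to compound 4 (1.94 log units; beyond the scatter), a large step that far exceeds either modest step at the aromatic carbon, so most of the low number of compound 1 goes with (1-bromoethenyl)carbonyl on that nitrogen rather than with ethoxy. No measured evidence is available to explain either step.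

As far as these compounds go, whether the response at this carbon is particular to ethoxy remains open, since a methoxy group or a longer chain such as butoxy could give a smaller or a larger step. Also open, from the compounds shown here alone, is whether (1-bromoethenyl)carbonyl on the nitrogen would give a step of similar size on compound 2 or compound 3, which would show whether the changes at the two places act independently.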